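The source may hold more compounds than are shown below. What is called first, only, known or untested is meant among the compounds shown, and "the series" means these compounds.

The measured compounds and their values:

compound 1, `Nc1nc(Cl)c(-c2ccccn2)c(N[C@@H]2C[C@H](CO)[C@@H](O)[C@H]2O)n1`, in an ADME assay on cells (Homo sapiens) for cytotoxicity, read by polymerase chain reaction, with a stated time of 3 days; a lower number here means that less compound is tolerated, a higher number that more compound is tolerated: > 25000 nM, a limit of the assay, not a number.
compound 2, `Nc1nc(Cl)c(-c2nc3ccc(F)cc3s2)c(N[C@@H]2C[C@H](CO)[C@@H](O)[C@H]2O)n1`, in this assay: > 25000 nM, again a limit.
compound 3, `CCCNc1nc(C)c(-c2nc3ccccc3s2)c(N[C@@H]2C[C@H](CO)[C@@H](O)[C@H]2O)n1`, in this assay: > 25000 nM, again a limit.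

Compound 3 therefore stands where every measured compound stands: at the limit of > 25000 nM in this assay, at which 3 of the 3 values shown sit. Among the compounds with values here, no number separates it from compound 1 or compound 2, and no measured pair differs in a single place, so no measured step exists to lean on.

Compound 4, `Cc1nc(NCC2CCC2)nc(N[C@@H]2C[C@H](CO)[C@@H](O)[C@H]2O)c1-c1nc2ccccc2s1`, is not yet measured. It differs from compound 3 by cyclobutyl in place of ethyl on a saturated chain carbon bound to a nitrogen on an aromatic ring. Everything else in the two structures is the same.

With all three measured compounds sitting at the limit, the expectation for the step from compound 3 to compound 4 is no change beyond the usual scatter, and the step of a number no higher from compound 3 to compound 4 (the limit leaves the size open) expresses that. Compound 4 is expected to read 25000 nM in this assay, between 12000 nM and 50000 nM, most probably reported as a limit rather than as a number. Whether the cyclobutyl group alters what the cells tolerate is something only the measurement can show.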

Compound 4, half-maximal cytotoxic concentration: > 25000 nM
Compound 4: only a limit was reported; the forecaster's own chance of this, stated with the estimate: 80%; the middle value lies on the limit itself.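

In this assay compound 4 gives > 25000 nM, a limit of the assay and not a number. Within the data shown here, compound 3 also carries only a limit, so no step between compound 3 and compound 4 can be read. The compounds shown leave open how much of each the cells would tolerate, and whether cyclobutyl in place of ethyl changes that at all: the limit of > 25000 nM in this assay, at which 4 of the 4 values shown sit.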